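A Methoxy Swap on the Propylamino Chain

The source may report more compounds than this note shows. Statements on the series, on what has been measured and on what is new or still open speak of the compounds shown alone.

Compound 3 `CCCNc1nc(C)c(-c2nc3ccccc3s2)c(N[C@@H]2C[C@H](CO)[C@@H](O)[C@H]2O)n1` was examined in an ADME assay on cells (Homo sapiens) for cytotoxicity, read by polymerase chain reaction, with a stated time of 3 days; a lower number here means that less compound is tolerated, a higher number that more compound is tolerated. In this assay compound 3 gives > 25000 nM, which is a limit of the assay and not a number. Compound 1 `Nc1nc(Cl)c(-c2nccs2)c(N[C@@H]2C[C@H](CO)[C@@H](O)[C@H]2O)n1` also reaches a limit in this assay, namely > 25000 nM. Compound 2 `CN(C)c1ccc2sc(-c3c(Cl)nc(N)nc3N[C@@H]3C[C@H](CO)[C@@H](O)[C@H]3O)nc2c1` yields a number in this assay, 25000 nM. Thus the limit of > 25000 nM in this assay, at which 2 of the 3 values shown sit, describes where compound 3 stands. Compound 4 `COCCNc1nc(C)c(-c2nc3ccccc3s2)c(N[C@@H]2C[C@H](CO)[C@@H](O)[C@H]2O)n1` differs from compound 3 by methoxy in place of methyl on a saturated chain carbon, two bonds along the chain from a nitrogen on an aromatic ring. Within the data shown here, no step between measured compounds is known here, so the change is expected to bring no shift beyond the scatter in this assay, with the estimated step being a number no higher from compound 3 to compound 4 (the limit leaves the size open). Compound 4 is therefore expected at 25000 nM, within 12000 nM to 50000 nM, and most likely reported again as a limit.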

Compound 4, half-maximal cytotoxic concentration: 21000 nM
Beside the measured number, compound 4's estimate is 1.2-fold (0.08 log units) above it, and the stated range covers the measured number.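

Methoxy in place of methyl at this position turns a limit into a number in this assay, with an at least 1.1-fold lower number from compound 3 to compound 4 (0.07 log units; that floor lies within the scatter). The value for compound 3 is a limit, so this step has a floor but no known size, and the floor does not establish a real change. Compound 4 therefore still sits near the limit that marks this set of compounds: the limit of > 25000 nM in this assay, at which 2 of the 4 values shown sit.

Going by these compounds, what a longer chain, or an amine or a carboxylic acid at the end of the chain, would give in this assay remains open.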